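Working notes: aryl replacement from compound 1 to compound 4

The source may report more compounds than this note shows. Statements on the series, on what has been measured and on what is new or still open speak of the compounds shown alone.

Compound 1 `COc1ccc(OC)c(C2OC(c3cc(OC)c(OC)c(OC)c3)=NN2C(C)=O)c1` in a functional assay on PC-3 cells (Homo sapiens) for antiproliferative activity, read by MTT assay, tested at 5 uM (on this read-out lower numbers stand for a weaker effect and higher numbers for a stronger effect at the one concentration tested), gives 43.2%. Compound 2 `COc1cc(C(=O)N/N=C/c2c(Cl)cccc2Cl)cc(OC)c1OC` gives 52.1% in this assay, and compound 3 `COc1cc(C(=O)N/N=C/c2cc(Cl)cc(Cl)c2)cc(OC)c1OC` gives 46.3% in this assay. Compound 1 holds the lowest of the three numbers, but its gap to compound 3 and its gap to compound 2 both stay within the scatter, so no order among the three can be read from these figures.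

Compound 4 `COc1cc(C2=NN(C(C)=O)C(c3cccc(C(F)(F)F)c3)O2)cc(OC)c1OC` has not yet been measured in this assay. It differs from compound 1 by 3-(trifluoromethyl)phenyl in place of 2,5-dimethoxyphenyl on a saturated ring carbon. Within the data shown here, the one measured step, a number 5.8 percentage points lower from compound 2 to compound 3 (within the scatter), concerns a change of the dichloro pattern on a carbon with a double bond to nitrogen in the other core and lies within the scatter; it does not involve the saturated ring carbon of the core of compound 1 and gives no guide for an exchange of one aryl group for a quite different one at that position. Nothing measured therefore supports a step beyond the scatter in either direction, and the range has to be kept wide. In this assay compound 4 is expected to give about 43%, within 25% to 60%. The step this estimate means, a number 0.2 percentage points lower from compound 1 to compound 4 (within the scatter), is expected to stay within the scatter.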

Compound 4, a percentage reported as inhibition, at one concentration (the size of the read-out at that concentration, not a potency): 43.6%
Compound 4: middle estimate off by 0.6 percentage points, on the low side, and the stated range covers the measured number.
By their numbers in this assay, from the lowest: compounds 1, 4, 3 and 2 (each within the scatter of the next).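

In this assay, among these compounds, placing 3-(trifluoromethyl)phenyl instead of 2,5-dimethoxyphenyl on the saturated ring carbon of the shared core gives a number 0.4 percentage points higher from compound 1 to compound 4 (within the scatter), the first measured exchange at this position. The read-out therefore does not separate these two aryl groups, although the entering group has 0 hydrogen-bond acceptors and the leaving group has 2, while both have 10 heavy atoms and one six-membered aromatic ring of carbon only. No measured information on hand offers an explanation for this result.

Going by these compounds, it remains open whether a phenyl ring bearing an amine or a carboxylic acid on this saturated ring carbon, or a non-aromatic group such as a longer alkyl chain there, would give a step beyond the scatter in this assay. Also open, on these data alone, is whether the same indifference to the aryl group would hold if a longer acyl chain took the place of the acetyl group on the ring nitrogen, since the two compounds compared here both carry the acetyl group.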